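Working notes: difluorophenyl to dichlorophenyl

A few compounds are considered here, and "the series" means these few. Any claim that something is new, unique, unknown or untested is made for them only; others in the source may bear on it.

compound 1 `COc1ccc(/C=C/[C@@](C)(/C=C/c2ccc(O)c(/C=C/C(=O)c3ccccc3)c2)CCC=C(C)C)cc1` gives > 26000 nM, a limit
compound 2 `C=C[C@@](C)(/C=C/c1ccc(Nc2ccc(F)c(F)c2)cc1)CCC=C(C)C` gives > 26000 nM, a limit

Both readings come from a functional assay on Raji cells (Homo sapiens) for cytotoxicity, with a stated time of 72 h; on this read-out lower numbers stand for an effect already at smaller amounts and higher numbers for an effect only at larger amounts of compound. The standing of compound 2 is the limit of > 26000 nM in this assay, at which 2 of the 2 values shown sit, so it offers a limit and no number. Compound 3 `C=C[C@@](C)(/C=C/c1ccc(Nc2ccc(Cl)c(Cl)c2)cc1)CCC=C(C)C` differs from compound 2 in one place (3,4-dichlorophenyl in place of 3,4-difluorophenyl on a nitrogen on an aromatic ring), with 3,4-dichlorophenyl in place of 3,4-difluorophenyl on a nitrogen on an aromatic ring. For the measured compounds named here, no measured step exists to size this change, so no shift beyond the scatter is expected in this assay, in either direction. The assay will most likely report a limit again. The expected step is a number no higher from compound 2 to compound 3 (the limit leaves the size open). For compound 3 the estimated value is 26000 nM, with an expected range from 10000 nM to 60000 nM.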

Compound 3, half-maximal effective concentration: > 26000 nM
Compound 3 gave a limit, no number; the forecaster's own chance of this, stated with the estimate: 70%; the middle value lies on the limit itself.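

The step between compound 2 and compound 3 cannot be read, because both readings are limits and not numbers: the limit of > 26000 nM in this assay, at which 3 of the 3 values shown sit.

The compounds shown leave open how 3,4-dichlorophenyl compares with 3,4-difluorophenyl at this nitrogen, and which change, if any, would give a readable number.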